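Aminophenyl for Phenylethyl on the Amine of Compound 1

The compounds below may be only part of what the source reports. "The series", "measured", "known", "first", "only" and "open" are said of these compounds alone.

Measured compounds:
- compound 1, `C[C@@H](Nc1c(C(=O)NCc2ccc(F)cc2)nc(Br)c2cccnc12)c1ccccc1`: "not determined" (no result reported)
- compound 2, `N[C@H]1CC[C@H](Nc2c(C(=O)NCc3ccc(F)cc3)nc(N3CCCCS3(=O)=O)c3cccnc23)CC1`: 13000 nM

Compound 1, `C[C@@H](Nc1c(C(=O)NCc2ccc(F)cc2)nc(Br)c2cccnc12)c1ccccc1`, has no number in a functional assay on MCF7 cells (Homo sapiens) for cytotoxicity, read by MTT assay, with a stated time of 72 h; a higher number here means a weaker inhibitor, a lower number a stronger inhibitor; its result is recorded as "not determined" (no result reported), so it stands nowhere on the scale. Compound 2, `N[C@H]1CC[C@H](Nc2c(C(=O)NCc3ccc(F)cc3)nc(N3CCCCS3(=O)=O)c3cccnc23)CC1`, differs from compound 1 in several places. In this assay compound 2 gives 13000 nM, a weak result. Compound 3, `Nc1cccc(Nc2c(C(=O)NCc3ccc(F)cc3)nc(Br)c3cccnc23)c1`, is the next step: 3-aminophenyl in place of 1-phenylethyl on a nitrogen on an aromatic ring. Among the compounds with values here, no step between measured compounds is available, so the size and direction of this change cannot be read from any pair; with compound 1 unmeasured, the expectation rests only on compound 2 and its 13000 nM as the one anchor for this core. Compound 3 is therefore expected to land at about 6000 nM, within 1000 nM to 40000 nM.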

Compound 3, half-maximal inhibitory concentration: 8000 nM
Compound 3: middle estimate off by 1.3-fold (0.12 log units), on the low side; the range from low to high includes it.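

No step can be read for compound 3, which differs from compound 2 in more than one place, while compound 1 stands at "not determined" (no result reported) and gives no number to compare. The compounds shown leave open what replacing 1-phenylethyl with 3-aminophenyl does in this assay on its own. Nothing shown bears on the reason for the result of compound 3.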